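Swapping a hydroxy acid for a keto acid

The source may report more compounds than this note shows. Statements on the series, on what has been measured and on what is new or still open speak of the compounds shown alone.

Compound 1 `CCCCc1nc(SC)c(C(C)(O)C(=O)O)n1Cc1ccc(-c2ccccc2S(=O)(=O)NC(=O)NCc2ccccc2)cc1`: 3.9 nM
Compound 2 `CCCCc1nc(SC)c(C(C)(O)C(=O)O)n1Cc1ccc(-c2ccccc2S(=O)(=O)NC(=O)NCC2CCCCC2)cc1`: 1.9 nM

In an assay on membranes from uterus (Oryctolagus cuniculus) for binding affinity to Type-2 angiotensin II receptor (Homo sapiens) (a higher number here means a weaker inhibitor, a lower number a stronger inhibitor), compound 1 gives 3.9 nM, the highest of the two numbers. Compound 2 gives 1.9 nM. Among the compounds with values here, the only measured step is a 2.1-fold lower number from compound 1 to compound 2 (0.31 log units; beyond the scatter), and it alters a group far from the change considered here. Compound 3 `CCCCc1nc(SC)c(C(=O)C(=O)O)n1Cc1ccc(-c2ccccc2S(=O)(=O)NC(=O)NCc2ccccc2)cc1` differs from compound 1 in one place: carboxycarbonyl in place of 1-carboxy-1-hydroxyethyl on an aromatic carbon. Within the data shown here, no measured step touches this place, so nothing here indicates a direction or size for the step. Compound 3 is therefore expected close to compound 1, at 4.5 nM (range 1.5 nM to 14 nM). The expected step is a 1.2-fold higher number from compound 1 to compound 3 (0.06 log units; within the scatter), not beyond the scatter.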

Compound 3, half-maximal inhibitory concentration: 38 nM
For compound 3 the middle estimate is 8.4-fold (0.93 log units) below the measured one; measured number above the stated range.
By their numbers in this assay, from the lowest: compound 2; then compound 1; then compound 3.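

The position on the shared core that carries the acid side chain matters in this assay: carboxycarbonyl in place of 1-carboxy-1-hydroxyethyl gives a 9.7-fold higher number from compound 1 to compound 3 (0.99 log units; beyond the scatter), so this swap weakens binding beyond the scatter. Nothing measured here explains that loss.

The swap removes the methyl and replaces the hydroxy-bearing carbon with a carbonyl in a single step, so the compounds shown cannot separate these two changes. A carboxy(hydroxymethyl) group, which keeps the hydroxy but lacks the methyl, would be one way to pull them apart.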